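This account rests on a few compounds, and the source may have more. Where it says the series, first, only, none or still open, it means among the compounds named here.

Measured compounds:
- compound 1, `CNC(=O)c1cc(Oc2ccc(NC(=O)c3nn(-c4ccc(C)cc4)c(=O)cc3C)cc2F)ccn1`: 11500 nM
- compound 2, `Cc1cc(=O)n(-c2cccc(F)c2)nc1C(=O)Nc1ccc(Oc2ncnc3ccsc23)cc1`: 9540 nM

In a functional assay on A549 cells (Homo sapiens) for cytotoxicity, read by MTT assay, with a stated time of 72 h (a higher number here means a weaker inhibitor, a lower number a stronger inhibitor), compound 1 gives 11500 nM. In this assay compound 2 gives 9540 nM. Compound 2 stands at one end of these two numbers, but the gap to compound 1 lies within the usual scatter of repeated measurements, so the two cannot be told apart on what is shown. Compound 3, `Cc1ccc(-n2nc(C(=O)Nc3ccc(Oc4ncnc5ccsc45)cc3)c(C)cc2=O)c(C)c1`, has not been measured in this assay. It differs from compound 2 in one place: 2,4-dimethylphenyl in place of 3-fluorophenyl on an aromatic nitrogen. Among the measured compounds shown here, no step between two measured compounds covers this kind of change, so nothing in the data shows how large a step to expect. For the measured compounds named here, with two compounds that sit together within the scatter and no comparable step, the expectation is that the step from compound 2 to compound 3 stays small, in no fixed direction, and is estimated as a 1.0-fold higher number from compound 2 to compound 3 (0.02 log units; within the scatter) in this assay. Compound 3 is therefore expected to give about 10000 nM in this assay, with a range estimated from 3000 nM to 35000 nM.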

Compound 3, half-maximal inhibitory concentration: 16400 nM
The estimate for compound 3 lay 1.6-fold (0.21 log units) below the measured number; the range from low to high includes it.
By their numbers in this assay, from the lowest: compounds 2, 1 and 3 (each within the scatter of the next).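

In this assay, 2,4-dimethylphenyl in place of 3-fluorophenyl on the aromatic nitrogen gives a 1.7-fold higher number from compound 2 to compound 3 (0.24 log units; within the scatter). Among the compounds shown here, this is the first step that can be read at this position, and it shows that this exchange of one substituted phenyl group for another, with the fluorine gone and two methyl groups added, does not move the number beyond the scatter. The data offer no measurement that bears on what lies behind this result.

The compounds shown leave open whether this position responds at all, since the only groups seen on this nitrogen in a one-place comparison are two phenyl rings of carbon only, each carrying small substituents and neither having a hydrogen-bond donor or acceptor. A phenyl ring carrying a carboxylic acid or an amine, a pyridine ring, or a simple alkyl chain in place of the phenyl ring could show whether this nitrogen tolerates any group, or whether a step beyond the scatter can be found here in either direction.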